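Acid dissociation across a short series of diamine side chains

The source may hold more compounds than are shown below. What is called first, only, known or untested is meant among the compounds shown, and "the series" means these compounds.

Measured so far:
compound 1 `COc1ccc(Oc2ccc3c(NCCCNCc4cc(F)ccc4OC)ccnc3c2)cc1` — 9.28
compound 2 `c1ccc(-c2ccc3c(NCCCNCc4ccco4)ccnc3c2)cc1` — 9.47
compound 3 `Cc1cc(C)cc(Cc2ccc3c(NCCCNCc4ccco4)ccnc3c2)c1` — 9.47

In a physicochemical assay for acid dissociation, compound 3 stands level with compound 2 at the digits printed, and the two together are the highest of the three numbers; compound 1 lies a little lower, though that gap is within the scatter. For the measured compounds named here, the one step available, no change at the digits printed from compound 2 to compound 3 (within the scatter), changes the group on the aromatic carbon of the shared core and leaves the read-out unchanged within the scatter.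

Compound 4 `COc1ccc(Oc2ccc3c(NCCCNCc4ccco4)ccnc3c2)cc1` is not yet measured. It differs from compound 3 in one place: 4-methoxyphenoxy in place of 3,5-dimethylbenzyl on an aromatic carbon. The group that changes sits on the same aromatic carbon as in the step from compound 2 to compound 3, far from the secondary amine that is presumably titrated, and that step was flat. Compound 1 carries the same 4-methoxyphenoxy group together with a different benzyl group on the amine, and its value is within the scatter of compound 3, which supports only a small shift. The step of a number 0.07 log units lower from compound 3 to compound 4 (within the scatter) is therefore expected to be small, with a slight lean downward toward the number of compound 1. For compound 4 the estimate in this assay is 9.4, with a range from 9.15 to 9.65.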

Compound 4, acid dissociation constant: 9.28
Compound 4: the middle estimate sits 0.12 log units above what was measured; the range from low to high includes it.
By their numbers in this assay, from the lowest: compounds 1, 4, 2 and 3 (each within the scatter of the next).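

Working notes: in this assay, the aromatic carbon of the shared core has now carried phenyl, 3,5-dimethylbenzyl and 4-methoxyphenoxy, with a number 0.19 log units lower from compound 3 to compound 4 (within the scatter) and a number 0.19 log units lower from compound 2 to compound 4 (within the scatter) as the readings for the last exchange, so a group with two oxygens and two hydrogen-bond acceptors sits within the scatter of the carbon-only groups. The other end of the molecule can now be read as a single change with 4-methoxyphenoxy held fixed, and it gives no change at the digits printed from compound 1 to compound 4 (within the scatter) when furan-2-yl stands in place of 5-fluoro-2-methoxyphenyl on the saturated chain carbon bound to the amine nitrogen. Nothing available bears on the reason for these readings.

Open, from the compounds shown here alone, is whether a group of another kind on the same aromatic carbon, such as a carboxylic acid or a primary amine, would give a step beyond the scatter. Also open, going by these compounds, is whether a longer chain linking the two nitrogens, or a simple alkyl group in place of furan-2-yl, would leave the reading equally flat.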